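Taking away the carboxy: what compound 3 may show

A few compounds are considered here, and "the series" means these few. Any claim that something is new, unique, unknown or untested is made for them only; others in the source may bear on it.

Measured in a functional assay on SK-OV-3 cells (Homo sapiens) for inhibition, read by CCK-8 assay, with a stated time of 70 h; on this read-out higher numbers stand for weaker inhibition and lower numbers for stronger inhibition:
Compound 1 `c1ccc(COc2ccc(OCCOCCNC3CCCC3)cc2)cc1`: 24800 nM
Compound 2 `O=C(O)c1ccccc1COc1ccc(OCCOCCNC2CCCC2)cc1`: > 100000 nM (a limit of the assay, not a number)

Compound 2 stands at the limit of > 100000 nM in this assay, at which 1 of the 2 values shown sits, so it offers no exact starting point. Compound 3 `Nc1cccc(COc2ccc(OCCOCCNC3CCCC3)cc2)c1` has not yet been measured. It differs from compound 2 as follows: 3-aminophenyl in place of 2-carboxyphenyl on a saturated chain carbon bound to an oxygen on an aromatic ring. In words, it carries 3-aminophenyl in place of 2-carboxyphenyl on a saturated chain carbon bound to an oxygen on an aromatic ring. Among the measured compounds shown here, one measured step bears on this change, an at least 4.0-fold higher number from compound 1 to compound 2 (0.60 log units; beyond the scatter), which lies beyond the scatter and comes with carboxy in place of hydrogen on an aromatic carbon. Compound 3 has no carboxy, so its value is expected to return to the neighbourhood of compound 1 at 24800 nM. For the measured compounds named here, no measured step covers the amino group, which keeps the expectation broad. The step expected in this assay is an at least 5.0-fold lower number from compound 2 to compound 3 (0.69 log units; beyond the scatter), toward a lower number and stronger inhibition. For compound 3 the estimated value is 20000 nM, with an expected range of 7000 nM to 60000 nM.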

Compound 3, half-maximal inhibitory concentration: 10800 nM
Compound 3: the middle estimate sits 1.9-fold (0.27 log units) above what was measured; measured number inside the range.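

In this assay, 3-aminophenyl in place of 2-carboxyphenyl on a saturated chain carbon bound to an oxygen on an aromatic ring brings an at least 9.2-fold lower number from compound 2 to compound 3 (0.96 log units; beyond the scatter). Compound 2 gives only a limit of the assay and not a number, so this step has a floor but no known full size: the limit of > 100000 nM in this assay, at which 1 of the 3 values shown sits. Among the compounds shown here, what the earlier compounds could not show comes from the comparison with the unsubstituted parent: amino in place of hydrogen on an aromatic carbon gives a 2.3-fold lower number from compound 1 to compound 3 (0.36 log units; beyond the scatter), so compound 3 goes beyond merely regaining the level of compound 1, and a group on this aromatic ring can move the read-out toward stronger inhibition as well as toward weaker inhibition, as in an at least 4.0-fold higher number from compound 1 to compound 2 (0.60 log units; beyond the scatter).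

The compounds shown leave open whether this shift belongs to the amine itself or would also appear with another group on the same ring, such as a hydroxy group or an acetamide. They also leave open whether a methyl ester in place of the carboxylic acid would keep the read-out of compound 2 at its limit or bring it back toward compound 1.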